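Hydroxamic acids: chloro replaced by tert-butyl on the aryl tail

The source may hold more compounds than are shown below. What is called first, only, known or untested is meant among the compounds shown, and "the series" means these compounds.

Measured compounds:
compound 1, `Cc1ccccc1CN1CC=C(CCC(=O)NO)C1=O`, 4280 nM
compound 2, `O=C(CCC1=CCN(CCCc2ccc(Cl)cc2)C1=O)NO`, 2200 nM

The two measured compounds share one core bearing a hydroxamic acid chain and differ only in the group attached to the ring nitrogen. In a functional assay on NUGC-3 cells (Homo sapiens) for inhibition, read by sulforhodamine B assay (a lower number here means a stronger inhibitor of growth, a higher number a weaker inhibitor of growth), compound 1 gives 4280 nM. In this assay compound 2 gives 2200 nM; the two numbers lie within the scatter of each other, so compound 2 stands level with compound 1 and no order can be drawn between them.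

Compound 3, `CC(C)(C)c1ccc(CCCN2CC=C(CCC(=O)NO)C2=O)cc1`, is not yet measured. It differs from compound 2 in one place: tert-butyl in place of chloro on an aromatic carbon. Among the measured compounds shown here, no measured step of this kind is available here, so the size of its effect is unknown. The expectation is that the step from compound 2 to compound 3 in this assay stays within the scatter, with no clear direction: a 1.2-fold lower number from compound 2 to compound 3 (0.06 log units; within the scatter). Compound 3 is accordingly estimated at 1900 nM, in the range 700 nM to 5000 nM.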

Compound 3, concentration for 50% growth inhibition: 2200 nM
Compound 3: middle estimate off by 1.2-fold (0.06 log units), on the low side, within the range that was stated.
By their numbers in this assay, from the lowest: compounds 2, 3 and 1 (each within the scatter of the next).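

In this assay the exchange of chloro for tert-butyl on this aromatic carbon, para to a large group, gives no change at the digits printed from compound 2 to compound 3 (within the scatter). Compounds 1 and 2 differ in the whole group on the ring nitrogen, so they said nothing about a single substituent on this ring; this step shows that one chlorine atom can give way to four carbon atoms here without any change that can be read in growth inhibition. Nothing available here bears on why the value stays level.

On these data alone, only chloro and tert-butyl are seen at this position, so it remains open whether a bare hydrogen, an amine or a carboxylic acid on the same carbon would leave the value just as level. As far as these compounds go, how a longer chain in the tail would read also remains open.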